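Cytotoxicity notes on a thiocarbamate series, toward compound 4

The source may hold more compounds than are shown below. What is called first, only, known or untested is meant among the compounds shown, and "the series" means these compounds.

Measured so far in an ADME assay on MT4 cells (Homo sapiens) for cytotoxicity, read by MTT assay; on this read-out lower numbers stand for higher toxicity in this test and higher numbers for lower toxicity in this test:
compound 1 `O=C1c2ccccc2C(=O)N1CCOC(=S)N(C(=O)c1cc(F)cc(F)c1)c1ccc(Cl)cc1` gives 59000 nM
compound 2 `O=C1c2ccccc2C(=O)N1CCOC(=S)N(C(=O)c1cccc(Cl)c1Cl)c1ccc(Cl)cc1` gives 54000 nM
compound 3 `Cc1ccc(N(C(=O)c2cc(F)cc(F)c2)C(=S)OCCN2C(=O)c3ccccc3C2=O)cc1` gives 54000 nM

All three numbers sit close together. The cores of compound 1 and compound 3 differ by methyl in place of chloro on an aromatic carbon; the step in this assay is a 1.1-fold lower number from compound 1 to compound 3 (0.04 log units; within the scatter). Compound 2 and compound 3 read level at the digits given, within the scatter, so no order between them is claimed.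

The change from compound 1 to compound 2 is 2,3-dichlorophenyl in place of 3,5-difluorophenyl on a carbonyl carbon; its step in this assay is a 1.1-fold lower number from compound 1 to compound 2 (0.04 log units; within the scatter), within the scatter.

Compound 4 `Cc1ccc(N(C(=O)c2cccc(Cl)c2Cl)C(=S)OCCN2C(=O)c3ccccc3C2=O)cc1` is not yet measured. It differs from compound 3 by 2,3-dichlorophenyl in place of 3,5-difluorophenyl on a carbonyl carbon, the same change as from compound 1 to compound 2, at the same place, now on the core of compound 3. The step from compound 3 to compound 4 in this assay is expected to be a 1.1-fold lower number from compound 3 to compound 4 (0.03 log units; within the scatter), beside the earlier step of a 1.1-fold lower number from compound 1 to compound 2 (0.04 log units; within the scatter), because compound 1 to compound 2 showed a 1.1-fold lower number from compound 1 to compound 2 (0.04 log units; within the scatter) and compound 3 starts from 54000 nM. This rests on a single prior instance of the change. Compound 4 is estimated at 50000 nM, between 25000 nM and 100000 nM.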

Compound 4, half-maximal cytotoxic concentration: 35000 nM
Compound 4: middle estimate off by 1.4-fold (0.15 log units), on the high side; the range from low to high includes it.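

In this assay, 2,3-dichlorophenyl in place of 3,5-difluorophenyl on a carbonyl carbon gives a 1.5-fold lower number from compound 3 to compound 4 (0.19 log units; within the scatter), and the two instances of this change do not separate: the same change on two cores in this assay, a 1.1-fold lower number (0.04 log units; within the scatter) from compound 1 to compound 2 and a 1.5-fold lower number (0.19 log units; within the scatter) from compound 3 to compound 4, 1.4-fold (0.15 log units) apart, within the scatter of two such steps. Methyl in place of chloro on an aromatic carbon gives a 1.5-fold lower number from compound 2 to compound 4 (0.19 log units; within the scatter), and its two instances do not separate either: the same change on two cores in this assay, a 1.1-fold lower number (0.04 log units; within the scatter) from compound 1 to compound 3 and a 1.5-fold lower number (0.19 log units; within the scatter) from compound 2 to compound 4, 1.4-fold (0.15 log units) apart, within the scatter of two such steps. This shows no dependence on the core for either change at the resolution of this test, but every step lies within the scatter, so it does not show that either change moves the number, or that the changes transfer reliably, since each rests on just two instances.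

As far as these compounds go, what an amine or a carboxylic acid would do in place of the methyl or chloro remains open, as does the effect of a longer chain on the thiocarbamate oxygen. Also open, from the compounds shown here alone, is whether any single change can produce a step beyond the scatter in this assay.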